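The source may hold more compounds than are shown below. What is called first, only, known or untested is meant among the compounds shown, and "the series" means these compounds.

Measured compounds:
Compound 1, `COc1ccc(S(=O)(=O)Nc2ccc(NS(=O)(=O)c3ccc(F)cc3)cc2)cc1`, in an assay for inhibition of liver carboxylesterase 1 (Homo sapiens), read by spectrophotometry (a higher number here means a weaker inhibitor, a lower number a stronger inhibitor), gives > 100000 nM, a limit of the assay rather than a number.
Compound 2, `Cc1ccc(S(=O)(=O)Nc2ccc(NS(=O)(=O)c3ccc(F)c(F)c3)cc2)cc1`, in this assay gives > 100000 nM, again a limit.
Compound 3, `O=S(=O)(Nc1ccc(NS(=O)(=O)c2ccc(F)cc2)cc1)c1ccc(F)cc1`, in this assay gives > 100000 nM, also a limit.

Compound 3 therefore stands at the same limit as the other two: the limit of > 100000 nM in this assay, at which 3 of the 3 values shown sit. Among the measured compounds shown here, the only measured step that reaches compound 3 is a step that the two limits leave unreadable from compound 1 to compound 3, and it gives no usable size. For the measured compounds named here, no measured step covers the change now in question.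

Compound 4, `Cc1ccc(S(=O)(=O)Nc2ccc(NS(=O)(=O)c3ccc(F)cc3)cc2)cc1`, differs from compound 3 as follows: methyl in place of fluoro on an aromatic carbon. Going by the values given here, nothing among the measured pairs shows this exchange, so the expectation rests on the whole set sitting at the limit and on the small size of the change. The step from compound 3 to compound 4 in this assay is expected to be a step that the limit leaves unreadable from compound 3 to compound 4, that is, no step beyond the scatter. Compound 4 is therefore estimated at 150000 nM, with a range from 50000 nM to 500000 nM, most likely reported as a limit again.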

Compound 4, inhibition constant: > 100000 nM
Compound 4: a limit, no number; the forecaster's own chance of this, stated with the estimate: 85%; the middle value does not contradict the limit.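

Among the compounds shown here, compound 4 adds only another limit in this assay, so no step from compound 1, compound 2 or compound 3 to compound 4 can be read: the limit of > 100000 nM in this assay, at which 4 of the 4 values shown sit.

The compounds shown leave open which change on the shared core, if any, would give a measurable inhibition constant.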